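The compounds below may be only part of what the source reports. "The series", "measured", "known", "first", "only" and "open" are said of these compounds alone.

Compound 1 `COc1ccccc1C#Cc1ccccc1C#CCCCCO` and compound 3 `COc1cccc(C#Cc2ccccc2C#CCCCCO)c1` share the same atoms joined differently; the difference between their cores is not broken down here. In a functional assay on SR cells (Homo sapiens) for cytotoxicity (on this read-out lower numbers stand for stronger inhibition of growth and higher numbers for weaker inhibition of growth), compound 1 gives 1000 nM, and compound 3 gives 1900 nM. Compound 2 `OCCCCC#Cc1ccccc1C#Cc1ccccc1C(F)(F)F` carries the change trifluoromethyl in place of methoxy on an aromatic carbon relative to compound 1, and in this assay compound 2 gives 400 nM, a step of a 2.5-fold lower number from compound 1 to compound 2 (0.40 log units; beyond the scatter). Compound 4 `OCCCCC#Cc1ccccc1C#Cc1cccc(C(F)(F)F)c1` carries the same kind of change relative to compound 3, namely (trifluoromethyl in place of methoxy on an aromatic carbon), though here the group sits meta to a large group rather than ortho to it. Because the earlier step was a 2.5-fold lower number from compound 1 to compound 2 (0.40 log units; beyond the scatter), a step of a 2.1-fold lower number from compound 3 to compound 4 (0.32 log units; beyond the scatter) is expected for compound 4 in this assay. The value of compound 4 is estimated at 900 nM, likely between 400 nM and 2000 nM.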

Compound 4, concentration for 50% growth inhibition: 18300 nM
For compound 4 the middle estimate is 20-fold (1.31 log units) below the measured one; the measured number lies above the stated range.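

In this assay, putting trifluoromethyl in place of methoxy gives a 9.6-fold higher number from compound 3 to compound 4 (0.98 log units; beyond the scatter). Set beside the earlier step, the same swap moves the number in opposite directions on the two cores: the same change on two cores in this assay, a 2.5-fold lower number (0.40 log units; beyond the scatter) from compound 1 to compound 2 and a 9.6-fold higher number (0.98 log units; beyond the scatter) from compound 3 to compound 4, 24-fold (1.38 log units) apart, beyond the scatter of two such steps. This shows that the size and direction of a step read on one core cannot simply be carried to another core in this series, but it does not show why the two cores differ, and two pairs give no general rule.

As far as these compounds go, it remains open whether another group on the same aromatic carbon, such as a nitrile or a chlorine atom, would behave as in compound 2 or as in compound 4. From the compounds shown here alone, it also remains open whether the two cores would still part ways with an amine in place of the hydroxyl at the end of the chain.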